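A few compounds are considered here, and "the series" means these few. Any claim that something is new, unique, unknown or untested is made for them only; others in the source may bear on it.

Among the compounds with values here, compound 2 `COc1cccnc1-c1cc(Cl)ccc1NS(=O)(=O)c1ccc(C(C)(C)C)cc1` is one of two compounds measured in a functional assay on isolated protein for antagonist activity at C-C chemokine receptor type 9 (Homo sapiens), read by calcium flux, with a stated time of 10 min; a lower number here means a stronger inhibitor, a higher number a weaker inhibitor; its companion, compound 1 `COc1ccnc(-c2cc(Cl)ccc2NS(=O)(=O)c2ccc(C(C)(C)C)cc2)c1`, differs from it only in the placement of the methoxy group on the pyridine ring. In this assay compound 1 gives 2500 nM, while compound 2 gives 958 nM, so that the step of a 2.6-fold lower number from compound 1 to compound 2 (0.42 log units; beyond the scatter) places compound 2 with the lowest number of the two.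

The next compound, compound 3 `CC(C)(C)c1ccc(S(=O)(=O)Nc2ccc(Cl)cc2-c2ncccc2N)cc1`, keeps the core of compound 2 and carries the change (amino in place of methoxy on an aromatic carbon), that is, amino in place of methoxy on an aromatic carbon of the six-membered aromatic ring with one nitrogen, ortho to a large group and two atoms from the ring nitrogen. Within the data shown here, no measured step involves a swap of this kind; the single step recorded, from compound 1 to compound 2, concerns only where the methoxy sits and was modest. With nothing that speaks directly to the amino substitution, a step of no more than modest size in either direction is expected, and most likely one within the scatter; the expected step is a 1.3-fold higher number from compound 2 to compound 3 (0.10 log units; within the scatter). Compound 3 is therefore estimated at 1200 nM, with a range from 400 nM to 3500 nM.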

Compound 3, half-maximal inhibitory concentration: 95 nM
Beside the measured number, compound 3's estimate is 13-fold (1.10 log units) above it; measured number outside the range, below it.
By their numbers in this assay, from the lowest: compound 3; then compound 2; then compound 1.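

Within the data shown here, on an aromatic carbon of a six-membered aromatic ring with 1 nitrogen, ortho to a large group and two atoms from the ring nitrogen, the earlier compounds showed only what moving the methoxy does, but here the group itself is exchanged: in this assay, amino in place of methoxy gives a 10-fold lower number from compound 2 to compound 3 (1.00 log units; beyond the scatter) and so shows that this position responds to what it carries, not only to where the methoxy sits. Set against the other methoxy isomer, 3-aminopyridin-2-yl in place of 4-methoxypyridin-2-yl gives a 26-fold lower number from compound 1 to compound 3 (1.42 log units; beyond the scatter), which leaves compound 3 with the lowest number of the three, both of its steps lying beyond the scatter. Nothing at hand explains why this exchange has the effect it has.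

The compounds shown leave open whether a hydroxyl, a methylamino group or an acetamido group at this position would give a number like that of compound 3. They also leave open whether the amino group would have a similar effect at the position that carries the methoxy in compound 1, or with another group in place of the chlorine or the tert-butyl.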